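The compounds below may be only part of what the source reports. "The series", "measured", "known", "first", "only" and "open" are said of these compounds alone.

Going by the values given here, compound 1 `COc1ccc(C(=O)N2CCN(Cc3nc4ccccc4n3Cc3cccc(C)c3)CC2)cc1` is one of two compounds measured in an assay on isolated protein for inhibition of aldehyde dehydrogenase 1A1 (Homo sapiens), read by spectrophotometry, tested at 10 uM (a lower number here means less inhibition, a higher number more inhibition at the concentration tested (going by the name of the read-out)), where compound 1 gives 55.5%. That is the higher of the two numbers: compound 2 `O=C(C1CC1)N1CCN(Cc2nc3ccccc3n2Cc2ccccc2F)CC1` gives 40.7% in this assay, a gap beyond the usual scatter, so compound 1 stands on top. Compound 3 `Cc1cccc(Cn2c(CN3CCN(C(=O)c4ccc(C#N)cc4)CC3)nc3ccccc32)c1` has not been measured yet. It differs from compound 1 in one place: cyano in place of methoxy on an aromatic carbon. Among the compounds with values here, no measured pair shows this exchange, so its effect is open; the step expected in this assay is a number 5.5 percentage points lower from compound 1 to compound 3 (within the scatter), nothing beyond the scatter. Compound 3 is thus estimated to give 50% in this assay, within a range from 30% to 70%.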

Compound 3, a percentage reported as inhibition, at one concentration (the size of the read-out at that concentration, not a potency): 20.8%
The estimate for compound 3 lay 29.2 percentage points above the measured number, and the stated range ends above it.
By their numbers in this assay, from the lowest: compound 3; then compound 2; then compound 1.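

In this assay, putting 4-cyanophenyl where 4-methoxyphenyl stood gives a number 34.7 percentage points lower from compound 1 to compound 3 (beyond the scatter) and shows that the group at this position matters. Methoxy and cyano match in heavy atoms and hydrogen-bond acceptors, so those counts alone do not set the number here. No measurement shown explains the step.

The compounds shown leave open whether an amine or a chlorine at this place would land nearer compound 1 or compound 3. They also leave open whether the same exchange would give a similar step with a different amide group.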